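Working notes on a small ether series and liver half-life

The source may report more compounds than this note shows. Statements on the series, on what has been measured and on what is new or still open speak of the compounds shown alone.

Compound 1 `CC(=O)c1ccc(CCCOc2c(C)cc(-c3noc(C(F)(F)F)n3)cc2C)o1` is the reference point. In an in vitro ADME assay on microsomes from liver (Simiiformes) (on this read-out lower numbers stand for a shorter-lived compound and higher numbers for a longer-lived compound), compound 1 gives 1.05 h. Compound 2 `Cc1ccc(CCCOc2c(C)cc(-c3noc(C(F)(F)F)n3)cc2C)cn1` carries 6-methylpyridin-3-yl in place of 5-acetylfuran-2-yl on a saturated chain carbon, three bonds along the chain from an oxygen on an aromatic ring and in this assay compound 2 gives 1.97 h, which corresponds to a 1.9-fold higher number from compound 1 to compound 2 (0.27 log units; within the scatter). Compound 3 `CC(=O)c1ccc(CCCOc2c(C)cc(-c3noc(C)n3)cc2C)o1` differs from compound 1 by methyl in place of trifluoromethyl on an aromatic carbon; in this assay compound 3 gives 0.617 h, a change of a 1.7-fold lower number from compound 1 to compound 3 (0.23 log units; within the scatter). Compound 3 and compound 2 are not joined by a single step, but their two values lie apart by more than the usual scatter.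

Compound 4 `Cc1ccc(CCCOc2c(C)cc(-c3noc(C)n3)cc2C)cn1` has not been measured. Relative to compound 3 it carries 6-methylpyridin-3-yl in place of 5-acetylfuran-2-yl on a saturated chain carbon, three bonds along the chain from an oxygen on an aromatic ring. This is the same change that separates compound 2 from compound 1, and the place where it sits is described in the same words for both pairs; the two cores differ by the methyl in place of trifluoromethyl already described. The change occurs twice among these four compounds, once measured and once not.

Among the compounds with values here, the step from compound 3 to compound 4 is expected to be about a 1.9-fold higher number from compound 3 to compound 4 (0.27 log units; within the scatter), resting on the single precedent of a 1.9-fold higher number from compound 1 to compound 2 (0.27 log units; within the scatter), with no second occurrence to test how far it carries over to the other core. Compound 4 is therefore estimated at 1.15 h, with a range from 0.6 h to 2.3 h.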

Compound 4, half-life: 1.37 h
Compound 4: middle estimate off by 1.2-fold (0.08 log units), on the low side; measured number inside the range.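

In this assay, 6-methylpyridin-3-yl in place of 5-acetylfuran-2-yl gives a 2.2-fold higher number from compound 3 to compound 4 (0.35 log units; beyond the scatter), and this step agrees with its earlier occurrence on the core of compound 1: the same change on two cores in this assay, a 1.9-fold higher number (0.27 log units; within the scatter) from compound 1 to compound 2 and a 2.2-fold higher number (0.35 log units; beyond the scatter) from compound 3 to compound 4, 1.2-fold (0.07 log units) apart, within the scatter of two such steps. Methyl in place of trifluoromethyl gives a 1.4-fold lower number from compound 2 to compound 4 (0.16 log units; within the scatter), and this step also agrees with its earlier occurrence: the same change on two cores in this assay, a 1.7-fold lower number (0.23 log units; within the scatter) from compound 1 to compound 3 and a 1.4-fold lower number (0.16 log units; within the scatter) from compound 2 to compound 4, 1.2-fold (0.07 log units) apart, within the scatter of two such steps. Each change therefore carried over between these two cores with no difference beyond the scatter, but this rests on a single set of four compounds, shows nothing about any other core, and gives no reason for the size of either step, which is modest and lies on either side of the scatter for the ring change.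

The compounds shown leave open whether the same agreement holds for other groups at the end of the chain, such as an unsubstituted phenyl ring, or for an amine or a carboxylic acid in place of the acetyl group. They also leave open whether it survives a longer chain between the ether oxygen and the terminal ring, or a larger group such as tert-butyl in place of methyl or trifluoromethyl.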